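The compounds below may be only part of what the source reports. "The series", "measured", "known", "first", "only" and "open" are said of these compounds alone.

Of the compounds shown here, three that share one core have been measured in an in vitro ADME assay on microsomes from liver (Mus musculus) for pharmacokinetics, read by LC-MS, with a stated time of 10 min, tested at 1 uM; on this read-out higher numbers stand for fast clearance and lower numbers for slow clearance: compound 1 `CN1C[C@H](C(=O)Nc2ccc(F)cc2)[C@@H](c2ccc(/C=C/C(=O)Nc3ccccc3N)cc2)C1` gives 34 mL/min/kg, compound 2 `Cc1ccc(NC(=O)[C@H]2CN(C)C[C@@H]2c2ccc(/C=C/C(=O)Nc3ccccc3N)cc2)cc1` gives 62 mL/min/kg, and compound 3 `CC(C)c1ccc(NC(=O)[C@H]2CN(C)C[C@@H]2c2ccc(/C=C/C(=O)Nc3ccccc3N)cc2)cc1` gives 54 mL/min/kg. The number for compound 3 cannot be told apart from the other two, since repeated measurements of this kind scatter by as much as these gaps.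

Compound 4 `CN1C[C@H](C(=O)Nc2cccc(F)c2)[C@@H](c2ccc(/C=C/C(=O)Nc3ccccc3N)cc2)C1` differs from compound 3 in a single place: 3-fluorophenyl in place of 4-isopropylphenyl on an amide-type nitrogen. In words, 3-fluorophenyl stands in place of 4-isopropylphenyl on an amide-type nitrogen.

Within the data shown here, no measured step makes exactly this change, but three measured steps exchange groups on an aromatic carbon: a 1.8-fold higher number from compound 1 to compound 2 (0.26 log units; within the scatter), a 1.6-fold higher number from compound 1 to compound 3 (0.20 log units; within the scatter) and a 1.1-fold lower number from compound 2 to compound 3 (0.06 log units; within the scatter). None of these exchanges stands out from the scatter, so no large step is expected here either. Compound 4 carries a fluoro group, as does compound 1 at 34 mL/min/kg, so the expectation leans a little toward that value.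

The estimated change is a 1.4-fold lower number from compound 3 to compound 4 (0.13 log units; within the scatter), which is expected to stay within the scatter. For compound 4 the estimate is 40 mL/min/kg, with an expected range of 20 mL/min/kg to 78 mL/min/kg.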

Compound 4, clearance: 56 mL/min/kg
For compound 4 the middle estimate is 1.4-fold (0.15 log units) below the measured one; the range from low to high includes it.
By their numbers in this assay, from the lowest: compounds 1, 3, 4 and 2 (each within the scatter of the next).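

In this assay, 3-fluorophenyl in place of 4-isopropylphenyl on the amide-type nitrogen gives a 1.0-fold higher number from compound 3 to compound 4 (0.02 log units; within the scatter), and 3-fluorophenyl in place of 4-methylphenyl gives a 1.1-fold lower number from compound 2 to compound 4 (0.04 log units; within the scatter), so neither exchange can be told apart from repeat-measurement noise, even though the incoming group has fewer heavy atoms than 4-isopropylphenyl. The new information is that the fluoro group can now be compared in two placements, since 3-fluorophenyl in place of 4-fluorophenyl gives a 1.6-fold higher number from compound 1 to compound 4 (0.22 log units; within the scatter), also within the scatter. Across all four compounds, then, neither the identity of this single substituent on the phenyl group nor the fluoro group's placement produces a step that stands clear of the scatter.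

As far as these compounds go, all four groups at this position are phenyl groups carrying one fluoro or alkyl substituent, so it remains open whether a phenyl group carrying an amine or a carboxylic acid, or a pyridine in place of the phenyl group, would give a step beyond the scatter. Nothing available explains the numbers seen for these compounds.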